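This account rests on a few compounds, and the source may have more. Where it says the series, first, only, none or still open, it means among the compounds named here.

Measured so far:
compound 1, `CC(C#CCn1ccnc1)N1CCCC1=O` — 2 mg/kg
compound 2, `Cc1cncn1CC#CC(C)N1CCCC1=O` — 0.45 mg/kg
compound 3, `COC(=O)N(C)CC#CCn1ccnc1` — > 100 mg/kg

In a functional assay on the whole organism for antagonist activity, with Mus musculus as the target (on this read-out lower numbers stand for an effect already at smaller amounts and higher numbers for an effect only at larger amounts of compound), compound 1 gives 2 mg/kg and compound 2 gives 0.45 mg/kg. The step between them, (methyl in place of hydrogen on an aromatic carbon), brings a 4.4-fold lower number from compound 1 to compound 2 (0.65 log units; beyond the scatter). Compound 3 stands on a different core; how its core differs from that of compound 1 is not broken down here. For compound 3 the value in this assay is a limit only, > 100 mg/kg, and not a measured number, so that compound 3 is one of the compounds sitting at the limit of > 100 mg/kg in this assay, at which 1 of the 3 values shown sits.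

For the measured compounds named here, compound 4, `COC(=O)N(C)CC#CCn1cncc1C`, is the counterpart of compound 3: the change methyl in place of hydrogen on an aromatic carbon is the same change as the one from compound 1 to compound 2, with the same surroundings of the place. If the step it made there were carried over, one would expect a similar lowering from compound 3 to compound 4 in this assay, estimated as an at least 1.2-fold lower number from compound 3 to compound 4 (0.09 log units; that floor lies within the scatter). Because the value of compound 3 is only the limit > 100 mg/kg, the starting point is not known, and a lowering of that size from a number somewhere past the limit may still leave compound 4 at or around the limit. Compound 4 is therefore expected to give about 80 mg/kg in this assay, with a plausible range from 20 mg/kg to 300 mg/kg, and a real chance that only a limit is reported again.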

Compound 4, dose for half-maximal effect: 3 mg/kg
Beside the measured number, compound 4's estimate is 27-fold (1.43 log units) above it; measured number below the stated range.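

In this assay, methyl in place of hydrogen on an aromatic carbon of the core of compound 3 brings an at least 33-fold lower number from compound 3 to compound 4 (1.52 log units; beyond the scatter), a large step that turns an inactive-looking compound into one with a measurable dose. The change lowers the number on both cores, so its direction carries over in this small set of two pairs, but its size does not: the same change on two cores in this assay, a 4.4-fold lower number (0.65 log units; beyond the scatter) from compound 1 to compound 2 and an at least 33-fold lower number (1.52 log units; beyond the scatter) from compound 3 to compound 4, at least 7.5-fold (0.87 log units) apart, beyond the scatter of two such steps

The value of compound 3 is only a limit, > 100 mg/kg, so the step on this core has a floor and no known upper end, and two cores do not show what the same change would bring on a third: the limit of > 100 mg/kg in this assay, at which 1 of the 4 values shown sits.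

The compounds shown leave open whether this step is specific to methyl, as an ethyl group or a chlorine atom on the same aromatic carbon would test, and whether a methyl on another carbon of the ring would bring a step of similar size. They also leave open which part of the two cores sets the size of the step, something that a further pair of compounds, with an amine or a simple ether in place of the carbamate or the lactam, could begin to separate.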